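The source may hold more compounds than are shown below. What is called first, only, known or untested is meant among the compounds shown, and "the series" means these compounds.

Three compounds share one core, a two-ring scaffold carrying a sulfonamide on one ring, and differ only in what the second ring carries. Compound 1 `COc1cc(/C=C/c2ccc(S(N)(=O)=O)cc2)cc(OC)c1` bears two methoxy groups. In a functional assay on OVCAR-8 cells (Homo sapiens) for inhibition (a lower number here means a stronger inhibitor of growth, a higher number a weaker inhibitor of growth), compound 1 gives 37900 nM. Compound 2 `NS(=O)(=O)c1ccc(/C=C/c2ccc(F)cc2)cc1` carries a single fluoro, and in this assay compound 2 gives 15200 nM. Compound 3 `NS(=O)(=O)c1ccc(/C=C/c2ccc(O)c(O)c2)cc1` carries two hydroxy groups, and in this assay compound 3 gives 16700 nM.

Among these three numbers compound 2 has the lowest. The number of compound 3 lies within the usual scatter of that of compound 2, so the two cannot be told apart here. Compound 1 stands apart, its number being beyond the scatter above that of compound 2.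

Compound 4 `CN(C)c1ccc(/C=C/c2ccc(S(N)(=O)=O)cc2)cc1` has not yet been measured. It differs from compound 2 in one place: dimethylamino in place of fluoro on an aromatic carbon. For the measured compounds named here, no pair of measured compounds here shows a step of this kind, so the size of this step has to be guessed rather than read off. The three measured numbers all lie in the same broad region, so a large move in either direction seems unlikely; a modest move toward a lower number, at the edge of the scatter, is the expectation here.

Compound 4 is therefore expected to give about 8000 nM in this assay, somewhere between 2500 nM and 30000 nM. The expected step of a 1.9-fold lower number from compound 2 to compound 4 (0.28 log units; within the scatter) is thus a small one, toward a lower number.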

Compound 4, concentration for 50% growth inhibition: 4950 nM
Compound 4: middle estimate off by 1.6-fold (0.21 log units), on the high side; measured number inside the range.
By their numbers in this assay, from the lowest: compound 4; then compounds 2 and 3 (each within the scatter of the next); then compound 1.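

For the compounds shown here, replacing fluoro with dimethylamino gives a 3.1-fold lower number from compound 2 to compound 4 (0.49 log units; beyond the scatter) in this assay, the first change at a single place in this set whose size can be read directly. It shows that the group on this aromatic carbon, para to a large group, can affect growth inhibition, and that a group with more heavy atoms and a hydrogen-bond acceptor is accepted here without loss of inhibition. This one pair cannot separate the contribution of the added heavy atoms from that of the acceptor, and nothing presented here explains the step.

On these data alone, a single step gives no trend, so it remains open whether a plain amine, a diethylamino group or a carboxylic acid at this same place would lower the number further, leave it unchanged or raise it. As far as these compounds go, it is also open whether placing dimethylamino elsewhere on this ring, or adding a second group alongside it, would keep the lower number seen with compound 4 4950 nM.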